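Working notes: from the methoxy group of compound 2

The compounds below may be only part of what the source reports. "The series", "measured", "known", "first", "only" and "open" are said of these compounds alone.

Measured in a functional assay on U-373MG ATCC cells (Homo sapiens) for inhibition, read by colorimetric assay and MTT assay, with a stated time of 72 h; on this read-out higher numbers stand for weaker inhibition and lower numbers for stronger inhibition:
- compound 1 `CCCCCCOc1ncc(-c2ccccc2OC)n1C`: "not determined" (no result reported)
- compound 2 `COc1ccccc1-c1cnc(OC)n1C`: > 100000 nM

Compound 2 gives > 100000 nM, which is a limit of the assay and not a number. Within the data shown here, it is the only reading, since compound 1 has no result, and no step between measured compounds exists.

Compound 3 `C=CCCOc1ncc(-c2ccccc2OC)n1C` has allyl in place of hydrogen on a saturated chain carbon bound to an oxygen on an aromatic ring, (allyl in place of hydrogen on a saturated chain carbon bound to an oxygen on an aromatic ring). The same difference reads methoxy to (but-3-en-1-yl)oxy.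

In this assay, a small step toward stronger inhibition is expected, though a result that again reaches the limit is about as likely. The expected step is an at least 1.2-fold lower number from compound 2 to compound 3 (0.09 log units; that floor lies within the scatter). The estimate for compound 3 is 80000 nM, with an expected range from 20000 nM to 300000 nM.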

Compound 3, half-maximal inhibitory concentration: 16000 nM
For compound 3 the middle estimate is 5.0-fold (0.70 log units) above the measured one; the whole stated range lies above it.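

The position carrying the methoxy group of compound 2 responds to change: in this assay, going from methoxy to (but-3-en-1-yl)oxy gives an at least 6.2-fold lower number from compound 2 to compound 3 (0.79 log units; beyond the scatter). Among these compounds, compound 3, at 16000 nM, provides the first actual number and a reference point for further changes at this position. The step has no upper bound because one end of it is an assay limit rather than a number: the limit of > 100000 nM in this assay, at which 1 of the 3 values shown sits.

The data do not separate the effect of the longer chain from that of its double bond, which a saturated butyl chain would help to resolve. From the compounds shown here alone, it also remains open whether an amine or a carboxylic acid at the end of the chain would be tolerated, or how far a longer chain would carry the trend.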